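Methylphenyl versus fluorophenyl at the end of the biaryl

The source may report more compounds than this note shows. Statements on the series, on what has been measured and on what is new or still open speak of the compounds shown alone.

Compound 1, `Cc1ccc(-c2ccc(-c3nc4ccc(S(C)(=O)=O)cc4[nH]3)cc2)cc1`, gives in an assay on isolated protein for inhibition of acyl-CoA desaturase 1 (Rattus norvegicus) (on this read-out lower numbers stand for stronger inhibition and higher numbers for weaker inhibition), only a limit, > 20000 nM. Compound 2, `CS(=O)(=O)c1ccc2nc(-c3ccc(-c4ccc(Cl)cc4)cc3)[nH]c2c1`, gives in this assay likewise only a limit, > 20000 nM. Compound 3, `CS(=O)(=O)c1ccc2nc(-c3ccc(-c4ccc(F)cc4)cc3)[nH]c2c1`, gives in this assay 25 nM.

Going by the values given here, compound 3 thus carries the only number among the three; the other two sit at the limit of > 20000 nM in this assay, at which 2 of the 3 values shown sit. The step of an at least 800-fold lower number from compound 1 to compound 3 (2.90 log units; beyond the scatter) and the step of an at least 800-fold lower number from compound 2 to compound 3 (2.90 log units; beyond the scatter) both show that the 4-fluorophenyl end of compound 3 is decisive, while the step that the two limits leave unreadable from compound 1 to compound 2 cannot be read from two limits.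

Compound 4, `Cc1cccc(-c2ccc(-c3nc4ccc(S(C)(=O)=O)cc4[nH]3)cc2)c1`, differs from compound 3 in one place: 3-methylphenyl in place of 4-fluorophenyl on an aromatic carbon. Among the compounds with values here, no measured pair tests a methyl placed this way. The closest evidence is the step of an at least 800-fold lower number from compound 1 to compound 3 (2.90 log units; beyond the scatter), where a methyl on that ring, at the position described as para to a large group, left compound 1 at a limit. Compound 4 is therefore expected to lose much of the potency of compound 3, with an estimated step of a 200-fold higher number from compound 3 to compound 4 (2.30 log units; beyond the scatter). The value of compound 4 in this assay is estimated at 5000 nM, with a range from 500 nM to 20000 nM, and a real chance that only a limit is reported.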

Compound 4, half-maximal inhibitory concentration: 319 nM
Compound 4: middle estimate off by 16-fold (1.20 log units), on the high side, outside the stated range (below it).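

Placing the methyl as in 3-methylphenyl rather than 4-methylphenyl gives an at least 62-fold lower number from compound 1 to compound 4 (1.79 log units; beyond the scatter), so in this assay a methyl on this end ring does not by itself leave a compound at the limit, and where the methyl sits on the ring decides the outcome for this pair. The 3-methylphenyl end also compares favourably with the 4-chlorophenyl end, with an at least 62-fold lower number from compound 2 to compound 4 (1.79 log units; beyond the scatter), but it does not match the 4-fluorophenyl end, as a 13-fold higher number from compound 3 to compound 4 (1.11 log units; beyond the scatter) shows, so a measurable number here does not mean that the methyl can replace the fluorine without loss. The steps from compound 1 and compound 2 give bounds and not sizes, as each of these two compounds gives only a limit: the limit of > 20000 nM in this assay, at which 2 of the 4 values shown sit.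

The compounds shown leave open whether the gain belongs to this placement in general or to the methyl alone, which 3-fluorophenyl and 3-chlorophenyl ends would test against compound 4. They also leave open how an unsubstituted phenyl, or a methoxy, an amine or a carboxylic acid on this ring, would compare with compound 3.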